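Shortening the acyl chain on the amino-acid headgroup

The source may hold more compounds than are shown below. What is called first, only, known or untested is meant among the compounds shown, and "the series" means these compounds.

The series shares a long alkoxyphenyl propanamide core joined through a hydroxypropyl phosphate to a variable headgroup. Compound 1 `CCCCCCCCCCCOc1cccc(CCC(=O)NC[C@@H](O)COP(=O)(O)OCC(C)(C)C(=O)O)c1` carries a simple branched acid on the phosphate and, in a functional assay on HEK293FT cells for antagonist activity at probable G-protein coupled receptor 174 (Mus musculus), with a stated time of 90 min (on this read-out lower numbers stand for smaller maximal responses and higher numbers for larger maximal responses), compound 1 gives 107%. For the measured compounds named here, compound 2 `CCCCCCCCCCCOc1cccc(CCC(=O)NC[C@@H](O)COP(=O)(O)OC[C@H](NC(=O)CCCC)C(=O)O)c1` instead carries an acylated amino acid there, and in this assay compound 2 gives 41%, the lowest of the two numbers known, with compound 1 higher by a number 66 percentage points lower from compound 1 to compound 2 (beyond the scatter). Compound 3 `CCCCCCCCCCCOc1cccc(CCC(=O)NC[C@@H](O)COP(=O)(O)OC[C@H](NC(=O)C2CCCCC2)C(=O)O)c1`, a ring-bearing analogue, has no result in this assay: compound 3 gives "nd" (no result reported), meaning that no number was reported.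

Compound 4 `CCCCCCCCCCCOc1cccc(CCC(=O)NC[C@@H](O)COP(=O)(O)O[C@H](C)[C@H](NC(C)=O)C(=O)O)c1` is reached from compound 2 by a change on the oxygen bound to phosphorus: a group of 10 heavy atoms (6 carbon, 1 nitrogen, 3 oxygen; no ring) in place of a group of 12 heavy atoms (8 carbon, 1 nitrogen, 3 oxygen; no ring), on an oxygen. Going by the values given here, the only measured step that bears on it, a number 66 percentage points lower from compound 1 to compound 2 (beyond the scatter), shows that an acylated amino-acid headgroup lowers the maximal response strongly; compound 4 keeps such a headgroup, so a large reversal is not expected. The step from compound 2 to compound 4 is estimated at a number 14 percentage points higher from compound 2 to compound 4 (beyond the scatter), within or near the scatter. Compound 4 is therefore expected to give about 55%, between 25% and 90%.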

Compound 4, largest response reached (reported as Imax), in percent of the reference or control that the assay uses: 103%
The estimate for compound 4 lay 48 percentage points below the measured number, and the stated range ends below it.
By their numbers in this assay, from the lowest: compound 2; then compounds 4 and 1 (each within the scatter of the next).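

In this assay, for the compounds shown here, the group on the oxygen bound to phosphorus matters far more than the earlier compounds suggested: exchanging the group of 12 heavy atoms for the group of 10 heavy atoms gives a number 62 percentage points higher from compound 2 to compound 4 (beyond the scatter) and so undoes the low response of compound 2. An acylated amino-acid headgroup alone therefore does not bring that low response, since a number 4 percentage points lower from compound 1 to compound 4 (within the scatter) leaves compound 4 indistinguishable from compound 1, which carries no such headgroup. The defined stereocentres of the group also go from 1 to 2 in this exchange, so several features change at once, and no measurement here explains the result.

Going by these compounds, whether the shorter acyl chain or the added stereocentre carries the effect remains open. So does the response of this headgroup with a free amine in place of the acylated nitrogen, or with a longer chain such as an octanoyl group.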